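An acetoxy group added to compound 1

The compounds below may be only part of what the source reports. "The series", "measured", "known", "first", "only" and "open" are said of these compounds alone.

For the measured compounds named here, in a functional assay on the whole organism for inhibition, with Rattus norvegicus as the target (on this read-out higher numbers stand for weaker inhibition and lower numbers for stronger inhibition), compound 1 (`O=C1ON=C(c2cccs2)/C1=C/c1ccccc1`) gives 4400 nM and compound 2 (`O=C1ON=C(c2cccs2)/C1=C/c1ccco1`) gives 5800 nM as the only other number so far. The two cannot be told apart, since the step of a 1.3-fold higher number from compound 1 to compound 2 (0.12 log units; within the scatter) stays within the scatter. Compound 3 (`CC(=O)Oc1ccc(/C=C2\C(=O)ON=C2c2cccs2)cc1`) keeps the core of compound 1 and differs from it by one change: acetoxy in place of hydrogen on an aromatic carbon in this case. This places acetoxy in place of hydrogen on an aromatic carbon, para to a large group. Going by the values given here, the single measured step swaps phenyl for furan-2-yl, so it bears on this change only loosely, and no measured compound carries a group at this place. The expected step is a 1.1-fold higher number from compound 1 to compound 3 (0.06 log units; within the scatter) and is not expected to exceed the scatter. In this assay the estimated value for compound 3 is 5000 nM with an expected range from 1800 nM to 14000 nM on repeated measurement.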

Compound 3, half-maximal inhibitory concentration: 4500 nM
The estimate for compound 3 lay 1.1-fold (0.05 log units) above the measured number, and the stated range covers the measured number.
By their numbers in this assay, from the lowest: compounds 1, 3 and 2 (each within the scatter of the next).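

Compound 3 is the first of these compounds to carry a group on the six-membered aromatic ring, and in this assay acetoxy in place of hydrogen on an aromatic carbon, para to a large group, gives a 1.0-fold higher number from compound 1 to compound 3 (0.01 log units; within the scatter) and so leaves it indistinguishable from compound 1. The earlier step replaced the whole phenyl ring with furan-2-yl, whereas this one shows that the phenyl ring of compound 1 can bear acetoxy at this place with no change beyond the scatter. Nothing at hand offers an explanation for this result.

This single group says little about how others would behave at this place, such as a hydroxy group, an amine or a carboxylic acid. On these data alone, it also remains open whether acetoxy on another carbon of the ring, or on the furan-2-yl ring of compound 2, would give a similar number.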